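This account rests on a few compounds, and the source may have more. Where it says the series, first, only, none or still open, it means among the compounds named here.

Compound 1 `COc1cc(C(=O)NS(=O)(=O)c2c(C)cccc2Cl)ccc1Cn1ccc2ccc(NC(=O)CC3CCCC3)cc21` stands highest of the two compounds measured in a functional assay (trachea) for antagonist activity, with Cavia porcellus as the target (on this read-out lower numbers stand for lower potency and higher numbers for higher potency (the scale is a negative logarithm)), where compound 1 gives 8.8. Compound 2 `CCCCC(CC)C(=O)Nc1ccc2ccn(Cc3c(OC)cc(C(=O)NS(=O)(=O)c4ccccc4)cc3OC)c2c1` gives 8 in this assay, a value that lies beyond the usual scatter below that of compound 1. Compound 3 `COc1cc(C(=O)NS(=O)(=O)c2ccccc2OC)ccc1Cn1ccc2ccc(NC(=O)CC3CCCC3)cc21` differs from compound 1 in a single place: 2-methoxyphenyl in place of 2-chloro-6-methylphenyl on a sulfonyl sulfur. Among the compounds with values here, no measured pair of compounds shows this change, so the expectation rests on the change alone. A modest loss in this assay is expected, so the step of a number 0.50 log units lower from compound 1 to compound 3 (beyond the scatter) is expected to point downward. Compound 3 is estimated at 8.3, within a range from 7.7 to 8.9.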

Compound 3, negative logarithm of the antagonist equilibrium constant: 9.7
Compound 3: the middle estimate sits 1.40 log units below what was measured; measured number above the stated range.
By their numbers in this assay, from the lowest: compound 2; then compound 1; then compound 3.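

On the sulfonyl sulfur, 2-methoxyphenyl in place of 2-chloro-6-methylphenyl gives a number 0.90 log units higher from compound 1 to compound 3 (beyond the scatter) in this assay. This position therefore responds strongly to the group it carries, and a ring with one oxygen-bearing group can outperform one with chlorine and methyl. Nothing available explains this gain.

Within the data shown here, the single step swaps all these groups at once, so the share of each remains unknown. As far as these compounds go, whether 2-ethoxyphenyl, 2-chlorophenyl or a butyl chain on the same sulfur would raise or lower the number also remains open.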